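Cytotoxicity notes on azido nucleoside series, methoxy to amino

The source may report more compounds than this note shows. Statements on the series, on what has been measured and on what is new or still open speak of the compounds shown alone.

Measured so far in an ADME assay on PBMC cells (Homo sapiens) for cytotoxicity, with a stated time of 5 days; a lower number here means a stronger inhibitor, a higher number a weaker inhibitor:
- compound 1 `[N-]=[N+]=N[C@H]1C[C@H](n2cnc3c(N)nc(F)nc32)O[C@@H]1CO`, where compound 1 gives 30100 nM
- compound 2 `COc1nc(NC2CC2)c2ncn([C@H]3C[C@H](N=[N+]=[N-])[C@@H](CO)O3)c2n1`, where compound 2 reaches only the assay limit > 100000 nM
- compound 3 `COc1nc(OC)c2ncn([C@H]3C[C@H](N=[N+]=[N-])[C@@H](CO)O3)c2n1`, where compound 3 reaches only the assay limit > 100000 nM

Compound 3 therefore stands at the limit of this assay, with no number of its own; the limit of > 100000 nM in this assay, at which 2 of the 3 values shown sit, holds compound 3 together with compound 2. Among the measured compounds shown here, the one measured step, a step that the two limits leave unreadable from compound 2 to compound 3, cannot be sized, since both ends are limits.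

Compound 4 `COc1nc(N)c2ncn([C@H]3C[C@H](N=[N+]=[N-])[C@@H](CO)O3)c2n1` differs from compound 3 by amino in place of methoxy on an aromatic carbon. For the measured compounds named here, no measured step covers an amino in place of a methoxy on this ring, so the size of the step in this assay cannot be read from the data; compound 1, which also carries an amino at the shared core, shows a number rather than a limit, but no step connects it to compound 4. Compound 4 is expected at 100000 nM, within 30000 nM to 300000 nM, meaning an estimated step of a number no higher from compound 3 to compound 4 (the limit leaves the size open) that is not readable against a limit.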

Compound 4, half-maximal inhibitory concentration: 35000 nM
Estimate against measurement, compound 4: 2.9-fold (0.46 log units) above; the measured number falls inside the stated range.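

In this assay, among the compounds shown here, amino in place of methoxy on this aromatic carbon gives an at least 2.8-fold lower number from compound 3 to compound 4 (0.45 log units; beyond the scatter), the first step that can be read at this position, though only as a lower bound on its size. Hydrogen in place of cyclopropyl on the nitrogen gives an at least 2.8-fold lower number from compound 2 to compound 4 (0.45 log units; beyond the scatter), so compound 4 has a number of its own while compound 2 and compound 3 stay at the assay limit: the limit of > 100000 nM in this assay, at which 2 of the 4 values shown sit.

Methoxy in place of fluoro on an aromatic carbon gives a 1.2-fold higher number from compound 1 to compound 4 (0.07 log units; within the scatter), so with the amino in place, this exchange shows no readable change.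

On these data alone, how a methylamino or dimethylamino group would read at this position remains open. As far as these compounds go, the full size of the steps from compound 2 and compound 3 also stays open, as both ends of the series at that level are limits rather than numbers.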